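The source may report more compounds than this note shows. Statements on the series, on what has been measured and on what is new or still open speak of the compounds shown alone.

Measured compounds:
compound 1 `COc1cc(-c2nn(-c3cccc(NC(=O)Nc4ccc(Cl)c(Cl)c4)c3)cc2-c2ccncc2)ccc1Cl` — 3110 nM
compound 2 `O=C(Nc1cccc(-n2cc(-c3ccncc3)c(-c3ccc(Cl)c(O)c3)n2)c1)Nc1ccc(Cl)c(Cl)c1` — 3160 nM
compound 3 `O=C(Nc1cccc(-n2cc(-c3ccncc3)c(-c3ccc(Cl)c(O)c3)n2)c1)Nc1cc(C(F)(F)F)cc(C(F)(F)F)c1` — 2550 nM

In a functional assay on UACC-257 cells (Homo sapiens) for inhibition, read by sulforhodamine B assay, with a stated time of 48 h (on this read-out higher numbers stand for weaker inhibition of growth and lower numbers for stronger inhibition of growth), compound 1 stands second highest of the three numbers; compound 2 and compound 3 lie nearest and furthest, both within the scatter of compound 1. For the measured compounds named here, the only single-point step, a 1.0-fold higher number from compound 1 to compound 2 (0.01 log units; within the scatter), lies within the scatter.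

Compound 4 `COc1cc(-c2nn(-c3cccc(NC(=O)c4ccccc4)c3)cc2-c2ccncc2)ccc1Cl` differs from compound 1 by phenyl in place of (3,4-dichlorophenyl)amino on a carbonyl carbon. Going by the values given here, no measured step bears on this change; the one step known, a 1.0-fold higher number from compound 1 to compound 2 (0.01 log units; within the scatter), touches a different part of the shared core and is within the scatter, so the three measured values give no direction for it. A moderate step toward weaker growth inhibition is nevertheless expected in this assay: a 2.1-fold higher number from compound 1 to compound 4 (0.32 log units; beyond the scatter). Compound 4 is estimated at 6500 nM, with a range of 2500 nM to 17000 nM.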

Compound 4, concentration for total growth inhibition: > 100000 nM
Compound 4: no number, only a limit (the forecaster's own chance of this, stated with the estimate: 15%); middle value at least 15-fold (1.18 log units) away from the limit.
By their numbers in this assay, from the lowest: compounds 3, 1 and 2 (each within the scatter of the next). At a limit, above all of these: compound 4.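

In this assay compound 4 reads as a limit of the assay, not a number: the limit of > 100000 nM in this assay, at which 1 of the 4 values shown sits.

Phenyl in place of (3,4-dichlorophenyl)amino on a carbonyl carbon gives the first step in the series beyond the scatter: an at least 32-fold higher number from compound 1 to compound 4 (1.50 log units; beyond the scatter). The only earlier step, a 1.0-fold higher number from compound 1 to compound 2 (0.01 log units; within the scatter), lies within the scatter and concerns a different place, so this carbonyl substituent is the one place shown where a change moves the read-out.

The change removes the amino nitrogen and both chlorines together, and the compounds shown do not separate these. Unchlorinated phenylamino or 3,4-dichlorophenyl directly on the carbonyl carbon would address this.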